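A few compounds are considered here, and "the series" means these few. Any claim that something is new, unique, unknown or untested is made for them only; others in the source may bear on it.

Of the compounds shown here, three with a shared core have been measured in an assay on HEK293 cells for displacement of a labelled ligand from Melanocortin receptor 4 (Homo sapiens); on this read-out lower numbers stand for stronger inhibition and higher numbers for weaker inhibition. Compound 1 `CCCCC(N)c1cc(C(F)(F)F)ccc1N1CCN(C(=O)CCc2ccc(Cl)cc2Cl)CC1` gives 190 nM. Compound 2 `CC(C)C[C@H](N)c1cc(C(F)(F)F)ccc1N1CCN(C(=O)CCc2ccccc2Cl)CC1` gives 1700 nM. Compound 3 `CC(C)C[C@H](N)c1cc(C(F)(F)F)ccc1N1CCN(C(=O)CCc2ccccc2O)CC1` gives 3300 nM, the highest of the three numbers; the gap from compound 1 to compound 3 is beyond the scatter, while the step of a 1.9-fold higher number from compound 2 to compound 3 (0.29 log units; within the scatter) lies within it, so compound 2 and compound 3 cannot be told apart on this read-out.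

Compound 4 `Cc1cccc(CCC(=O)N2CCN(c3ccc(C(F)(F)F)cc3[C@@H](N)CC(C)C)CC2)c1` has not yet been measured in this assay. It differs from compound 3 in one place: 3-methylphenyl in place of 2-hydroxyphenyl on a saturated chain carbon, two bonds along the chain from a carbonyl carbon. Going by the values given here, the only measured step that touches this part of the molecule is the change from chloro to hydroxy on that same aromatic ring, a 1.9-fold higher number from compound 2 to compound 3 (0.29 log units; within the scatter), which did not move the number beyond the scatter. Among the compounds with values here, no measured pair shows what a methyl on this ring does, and compound 1 differs in two places at once, so it cannot be read as a single step. The expectation is therefore a step of a 1.7-fold lower number from compound 3 to compound 4 (0.22 log units; within the scatter), small and not clearly beyond the scatter, with the number most likely landing near that of compound 2. Compound 4 is estimated at 2000 nM in this assay, with a range from 700 nM to 6000 nM.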

Compound 4, inhibition constant: 2100 nM
Compound 4: the middle estimate sits 1.1-fold (0.02 log units) below what was measured; the range from low to high includes it.
By their numbers in this assay, from the lowest: compound 1; then compounds 2, 4 and 3 (each within the scatter of the next).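

Replacing the ring group on a saturated chain carbon, two bonds along the chain from a carbonyl carbon, gives in this assay a 1.6-fold lower number from compound 3 to compound 4 (0.20 log units; within the scatter) and also a 1.2-fold higher number from compound 2 to compound 4 (0.09 log units; within the scatter) as a second comparison, so neither change can be told from the scatter. This extends the earlier chloro-to-hydroxy result: 2-chlorophenyl, 2-hydroxyphenyl and 3-methylphenyl cannot be separated here, even though 2-hydroxyphenyl carries one hydrogen-bond donor and one hydrogen-bond acceptor and 3-methylphenyl carries neither. No measurement at hand offers an explanation for this flat result, and these swaps change both the group and its place on the ring, so the two contributions cannot be separated.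

Still open, going by these compounds, is whether a carboxylic acid or an amine on this ring would move the number beyond the scatter, since all three groups so far leave it unresolved. Compound 1 gives 190 nM but differs from the others in more than one place, so the compounds shown do not reveal which of its features matters, and a single-change partner, such as a longer chain paired with an otherwise identical ring, would be needed.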